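Chloro in place of methyl: compound 2 to compound 3

The compounds below may be only part of what the source reports. "The series", "measured", "known", "first", "only" and "open" are said of these compounds alone.

In a functional assay on RAW264.7 cells (Mus musculus) for inhibition, with stated times of 2 h and 24 h (a lower number here means a stronger inhibitor, a higher number a weaker inhibitor), compound 1 `COc1ccc([C@@H]2c3c(OC)cc(OC)cc3C(SCc3ccc(Cl)cc3)[C@H]2c2cc(OC)cc(OC)c2)cc1` gives > 200000 nM, which is a limit of the assay and not a number. Among the measured compounds shown here, compound 2 `COc1ccc([C@@H]2c3c(OC)cc(OC)cc3C(C(O)c3ccc(C)cc3)[C@H]2c2cc(OC)cc(OC)c2)cc1` gives 26500 nM, the only true number so far. Compound 3 `COc1ccc([C@@H]2c3c(OC)cc(OC)cc3C(C(O)c3ccc(Cl)cc3)[C@H]2c2cc(OC)cc(OC)c2)cc1` differs from compound 2 by chloro in place of methyl on an aromatic carbon, para to a large group. For the measured compounds named here, the single measured step, an at least 7.5-fold lower number from compound 1 to compound 2 (0.87 log units; beyond the scatter), exchanges the whole (4-chlorobenzyl)sulfanyl group for hydroxy(4-methylphenyl)methyl, so it bears on this change only loosely. Going by the values given here, no measured step isolates methyl against chloro, and no shift beyond the scatter is expected in this assay. The expected change is a 1.1-fold lower number from compound 2 to compound 3 (0.03 log units; within the scatter). For compound 3 the estimated value is 25000 nM, with an expected range of 10000 nM to 65000 nM.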

Compound 3, half-maximal inhibitory concentration: > 200000 nM
Compound 3 gave a limit, no number (the forecaster's own chance of this, stated with the estimate: 12%); middle value at least 8.0-fold (0.90 log units) from the limit.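

In this assay compound 3 gives > 200000 nM, a limit of the assay and not a number. On this aromatic carbon, para to a large group, chloro in place of methyl gives an at least 7.5-fold higher number from compound 2 to compound 3 (0.87 log units; beyond the scatter), so the hydroxy-bearing linker present in compound 2 and compound 3 does not by itself give a readable inhibition value in this series. The step from compound 1 to compound 3 cannot be read, and the new step is bounded on one side only: the limit of > 200000 nM in this assay, at which 2 of the 3 values shown sit.

On these data alone, how far compound 3 lies past the limit stays open. Also open, as far as these compounds go, is how fluoro, methoxy, an amine or a longer alkyl chain on this aromatic carbon would read in this assay, and so whether the methyl of compound 2 is specifically required.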